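Substituent swap on the shared core, single-point binding

The source may report more compounds than this note shows. Statements on the series, on what has been measured and on what is new or still open speak of the compounds shown alone.

Measured so far:
compound 1 `CN1CCCN(CCn2ccc3ccc(C(N)=O)cc32)CC1` — 33%
compound 2 `CN1CCCN(CCn2ccc3ccc(OCc4ccccc4)cc32)CC1` — 28%

Of the compounds shown here, two have been read in an assay on HEK293 cells for binding affinity to 5-hydroxytryptamine receptor 7 (Homo sapiens), read by radioligand binding, tested at 1 uM; a lower number here means less inhibition, a higher number more inhibition at the concentration tested (going by the name of the read-out). Compound 1 `CN1CCCN(CCn2ccc3ccc(C(N)=O)cc32)CC1` gives 33% there; compound 2 `CN1CCCN(CCn2ccc3ccc(OCc4ccccc4)cc32)CC1` gives 28%. On the numbers shown compound 2 sits at the lower end of the pair, but the only comparison, a number 5 percentage points lower from compound 1 to compound 2 (within the scatter), stays within the scatter, so the two are not separated.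

Compound 3 `C=Cc1ccc2ccn(CCN3CCCN(C)CC3)c2c1` is next for this assay. The change from compound 2 is vinyl in place of benzyloxy on an aromatic carbon. Among the compounds with values here, the only measured step, a number 5 percentage points lower from compound 1 to compound 2 (within the scatter), also swaps the group on the same aromatic carbon and moved the read-out by nothing beyond the scatter; no measured step introduces vinyl. On that basis the step expected is a number 1 percentage points lower from compound 2 to compound 3 (within the scatter), in no direction beyond the scatter. The estimate for compound 3 is therefore 27%, with a range from 10% to 45%.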

Compound 3, a percentage reported as inhibition, at one concentration (the size of the read-out at that concentration, not a potency): 79%
Compound 3: the middle estimate sits 52 percentage points below what was measured; measured number outside the range, above it.
By their numbers in this assay, from the lowest: compounds 2 and 1 (each within the scatter of the next); then compound 3.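

Vinyl in place of benzyloxy gives a number 51 percentage points higher from compound 2 to compound 3 (beyond the scatter) in this assay and vinyl in place of carbamoyl gives a number 46 percentage points higher from compound 1 to compound 3 (beyond the scatter) at the same aromatic carbon. The position is therefore not indifferent to its substituent, something the pair of compound 1 and compound 2 could not show, since carbamoyl and benzyloxy are not separated there and only vinyl stands apart. No measurement at hand explains why vinyl stands apart.

On these data alone, whether the gain depends on the double bond of vinyl or simply on a group of only 2 heavy atoms stays open, and ethyl, ethynyl or a plain hydrogen on this carbon would tell those readings apart. As far as these compounds go, all three read-outs are single-concentration numbers, so how the compounds rank in potency also remains unknown.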